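From bromo to nitro on the core of compound 1

This account rests on a few compounds, and the source may have more. Where it says the series, first, only, none or still open, it means among the compounds named here.

In an ADME assay on CCRF-CEM cells (Homo sapiens) for cytotoxicity, read by cell counting (on this read-out higher numbers stand for lower toxicity in this test and lower numbers for higher toxicity in this test), compound 1 (`Cc1cc(C)cc(S(=O)(=O)c2c(C(=O)NCN3CCCC3)[nH]c3ccc(Br)cc23)c1`) gives 9600 nM as its half-maximal cytotoxic concentration. Compound 3 (`Cc1cc(C)cc(S(=O)(=O)c2c(C(=O)NCN3CCCCC3)[nH]c3ccc(Br)cc23)c1`) gives 10000 nM in the same measurement. Going by the values given here, the step between them (a 1.0-fold higher number from compound 1 to compound 3 (0.02 log units; within the scatter)) shows that the two stand level, and they are the only two exact numbers so far. Compound 2 (`Cc1cc(C)cc(S(=O)(=O)c2c(C(=O)NCCOc3ccccc3)[nH]c3ccc(Br)cc23)c1`) reads > 500000 nM as its result, which is a limit and not a number. Its step from the first compound (an at least 52-fold higher number from compound 1 to compound 2 (1.71 log units; beyond the scatter)) is large.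

Compound 4 (`Cc1cc(C)cc(S(=O)(=O)c2c(C(=O)NCN3CCCC3)[nH]c3ccc([N+](=O)[O-])cc23)c1`) keeps the side chain of compound 1 but carries nitro in place of bromo on an aromatic carbon. Every measured step lies on the saturated chain carbon bound to an amide-type nitrogen, and none lies at this aromatic carbon. They therefore offer no direct guide: one chain swap left the number level and the other moved it greatly. Among the compounds with values here, with no measured step at this place, the safest expectation is no step beyond the scatter, and the estimated step is small (a 1.0-fold higher number from compound 1 to compound 4 (0.02 log units; within the scatter)). The expected value for compound 4 is 10000 nM in this assay (estimated range 3000 nM to 35000 nM).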

Compound 4, half-maximal cytotoxic concentration: 12000 nM
Compound 4: middle estimate off by 1.2-fold (0.08 log units), on the low side; measured number inside the range.
By their numbers in this assay, from the lowest: compounds 1, 3 and 4 (each within the scatter of the next). At a limit, above all of these: compound 2.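

Until now every measured step lay on the saturated chain carbon bound to an amide-type nitrogen, so nothing was known about the aromatic carbon that carries bromo on the core of compound 1. In this assay, the change at that carbon gives a 1.3-fold higher number from compound 1 to compound 4 (0.10 log units; within the scatter), so this position now has a measured step, and it stays within the scatter even though the entering nitro has 3 heavy atoms and 2 hydrogen-bond acceptors where the leaving bromo has 1 heavy atom and none. The swap of these two groups at this place therefore leaves the number level on this side chain, but no measurement shown here accounts for that level result.

One swap at one aromatic carbon cannot show how far this tolerance reaches, so an amine, a carboxylic acid or a longer chain at the same place remains an open case. Also open, going by these compounds, is whether nitro would leave the number level on the other side chains, the piperidin-1-yl of compound 3 and the phenoxymethyl of compound 2.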